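This account rests on a few compounds, and the source may have more. Where it says the series, first, only, none or still open, it means among the compounds named here.

Compound 1 `COc1cc(/C=C2\CN(C)C/C(=C\c3ccc(Cl)cc3)C2=O)cc(OC)c1` and compound 2 `COc1cc(/C=C2\CN(C)C/C(=C\c3ccc(Br)cc3)C2=O)cc(OC)c1` share one core, and compound 3 `CN1C/C(=C\c2ccc(Cl)cc2)C(=O)/C(=C/c2cccc([N+](=O)[O-])c2)C1` and compound 4 `CN1C/C(=C\c2ccc(Br)cc2)C(=O)/C(=C/c2cccc([N+](=O)[O-])c2)C1` share another; how the two cores differ is not broken down here. In a functional assay on K562 cells (Homo sapiens) for cytotoxicity, read by MTT assay, with a stated time of 24 h (a higher number here means a weaker inhibitor, a lower number a stronger inhibitor), compound 1 gives 13300 nM and compound 2 gives 7420 nM. The change between them is bromo in place of chloro on an aromatic carbon, and it made a 1.8-fold lower number from compound 1 to compound 2 (0.25 log units; within the scatter). Compound 3 in this assay gives only a limit, > 20000 nM. The same change, (bromo in place of chloro on an aromatic carbon), leads from compound 3 to compound 4. Since the change left compound 1 and compound 2 within the scatter of each other, the number for compound 4 is expected to sit near the limit of compound 3, with a number no higher from compound 3 to compound 4 (the limit leaves the size open) as the expected step, and the value of compound 4 is estimated at 20000 nM, between 8000 nM and 60000 nM.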

Compound 4, half-maximal inhibitory concentration: > 20000 nM
Compound 4 gave a limit, no number; the forecaster's own chance of this, stated with the estimate: 60%; the middle value lies on the limit itself.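

Compound 3 and compound 4 both give only a limit in this assay, so no step can be read between them: the limit of > 20000 nM in this assay, at which 2 of the 4 values shown sit.

The compounds shown leave open whether bromo in place of chloro shifts the number on the core of compound 3.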